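Adding a bromoacryloyl amide to a thiazolidinedione scaffold

The source may hold more compounds than are shown below. What is called first, only, known or untested is meant among the compounds shown, and "the series" means these compounds.

Compound 1 `C=C(Br)C(=O)Nc1cccc(/C=C2\SC(=O)N(Cc3ccc(C)cc3)C2=O)c1`: in a functional assay on CCRF-CEM cells (Homo sapiens) for cytotoxicity, read by cell counting, with a stated time of 3 days (on this read-out higher numbers stand for weaker inhibition and lower numbers for stronger inhibition), compound 1 gives 1200 nM.
Compound 2 `Nc1cccc(/C=C2\SC(=O)N(Cc3ccccc3)C2=O)c1`: compound 2 reaches only the limit of this assay, > 250000 nM.

Compound 2 thus stands at the limit of > 250000 nM in this assay, at which 1 of the 2 values shown sits, with no number of its own. Compound 3 `C=C(Br)C(=O)Nc1cccc(/C=C2\SC(=O)N(Cc3ccccc3)C2=O)c1` differs from compound 2 by (1-bromoethenyl)carbonyl in place of hydrogen on a nitrogen on an aromatic ring. Because compound 1, which carries that same group, gives 1200 nM, the step from compound 2 to compound 3 is expected to be a large gain in potency, an at least 160-fold lower number from compound 2 to compound 3 (2.22 log units; beyond the scatter). Compound 3 is therefore estimated at 1500 nM, within 500 nM to 5000 nM.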

Compound 3, half-maximal inhibitory concentration: 510 nM
Estimate against measurement, compound 3: 2.9-fold (0.47 log units) above, within the range that was stated.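

On the nitrogen on the aromatic ring, the (1-bromoethenyl)carbonyl group now has a direct one-change comparison in this assay, and the result is an at least 490-fold lower number from compound 2 to compound 3 (2.69 log units; beyond the scatter) in potency terms. The methyl on an aromatic carbon matters far less, as hydrogen in its place gives a 2.4-fold lower number from compound 1 to compound 3 (0.37 log units; beyond the scatter) on the same read-out. Compound 2 has only a limit, not a number, so the full size of the first step stays unknown: the limit of > 250000 nM in this assay, at which 1 of the 3 values shown sits.

An acetyl or plain acryloyl group on that nitrogen would show whether the gain depends on the bromine. A chlorine or methoxy group in place of the methyl would widen the second comparison.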